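Swapping the sulfonyl cap of a pyrazoline for a piperidinyl amide

The compounds below may be only part of what the source reports. "The series", "measured", "known", "first", "only" and "open" are said of these compounds alone.

Measured so far:
compound 1, `CC1=NN(S(=O)(=O)c2ccc(C)cc2)C(c2cc(Br)cc(Br)c2O)C1` — "not active" (no number reported)
compound 2, `O=c1oc2ccccc2cc1C1=NN(S(=O)(=O)c2ccc([N+](=O)[O-])cc2)C(c2ccccc2)C1` — 41200 nM
compound 3, `Cc1ccc(S(=O)(=O)N2N=C(c3cc4ccccc4oc3=O)CC2c2ccccc2)cc1` — 50200 nM

In a functional assay on MGC-803 cells (Homo sapiens) for cytotoxicity, read by MTT assay, with a stated time of 48 h (a lower number here means a stronger inhibitor, a higher number a weaker inhibitor), compound 1, `CC1=NN(S(=O)(=O)c2ccc(C)cc2)C(c2cc(Br)cc(Br)c2O)C1`, was recorded as "not active" (no number reported), with no number reported. Compound 2, `O=c1oc2ccccc2cc1C1=NN(S(=O)(=O)c2ccc([N+](=O)[O-])cc2)C(c2ccccc2)C1`, gives 41200 nM in this assay, and compound 3, `Cc1ccc(S(=O)(=O)N2N=C(c3cc4ccccc4oc3=O)CC2c2ccccc2)cc1`, gives 50200 nM. Among the measured compounds shown here, the step of a 1.2-fold higher number from compound 2 to compound 3 (0.09 log units; within the scatter) is the only one between two measured compounds, and it lies within the scatter, so compound 3 stands level with compound 2 rather than above or below it.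

Compound 4, `CC1CCCCN1CC(=O)N1N=C(c2cc3ccccc3oc2=O)CC1c1ccccc1`, differs from compound 3 as follows: ((2-methylpiperidin-1-yl)methyl)carbonyl in place of (4-methylphenyl)sulfonyl on an amine nitrogen in a ring. For the measured compounds named here, no measured step bears on this change; the single known step concerns only a substituent on the aromatic ring of the sulfonyl group, which is itself removed here. The data therefore give no direction, and the expectation for this assay is a step not clearly beyond the scatter, with a wide range in both directions.

Compound 4 is expected to give about 45000 nM in this assay, between 12000 nM and 170000 nM, which corresponds to the estimated step of a 1.1-fold lower number from compound 3 to compound 4 (0.05 log units; within the scatter).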

Compound 4, half-maximal inhibitory concentration: "not active" (no number reported)
Compound 4: no number reported; the estimate stays without a comparison.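

In this assay compound 4 is recorded as "not active" (no number reported), so no step can be read between compound 3 and compound 4. Nothing shown here offers an explanation for this result. The compounds shown leave open how the ((2-methylpiperidin-1-yl)methyl)carbonyl group compares in size of effect with the (4-methylphenyl)sulfonyl group on the shared core.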